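The compounds below may be only part of what the source reports. "The series", "measured", "known", "first", "only" and "open" are said of these compounds alone.

Measured so far in a physicochemical assay for metabolic stability, read by LC-MS, in phosphate buffer, with a stated time of 120 min, at pH 7.4, tested at 1 uM; a lower number here means that less of the compound is left, a higher number that more of the compound is left:
compound 1 `CC#CCn1c(N2CCC[C@@H](N)C2)nc2c1c(=O)n(Cc1ccc(Br)cc1C(=O)OCC)c(=O)n2C`: 98.4%
compound 2 `CC#CCn1c(N2CCC[C@@H](N)C2)nc2c1c(=O)n(Cc1ccc(Cl)cc1C(=O)OCc1oc(=O)oc1C)c(=O)n2C`: 12%
compound 3 `CC#CCn1c(N2CCC[C@@H](N)C2)nc2c1c(=O)n(Cc1ccc(Br)cc1C(=O)OCc1oc(=O)oc1C)c(=O)n2C`: 8.32%

Compound 2 sits at the low end of these numbers, level with compound 3 and far from compound 1. Compound 4 `CC#CCn1c(N2CCC[C@@H](N)C2)nc2c1c(=O)n(Cc1ccc(Cl)cc1C(=O)OC)c(=O)n2C` alters compound 2 in one place: a hydrogen atom in place of a group of 7 heavy atoms (4 carbon, 3 oxygen; one five-membered aromatic ring with 2 hetero atoms), on a saturated chain carbon bound to an oxygen next to a carbonyl group.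

Going by the values given here, two measured steps bear on this change. The first is a number 90.1 percentage points lower from compound 1 to compound 3 (beyond the scatter). There, a group of 7 heavy atoms takes the place of one carbon atom, at the same place that changes here. Compound 4 loses that same group, so this large step is best read in reverse, as a rise. The second is a number 3.7 percentage points lower from compound 2 to compound 3 (within the scatter). Since bromo and chloro partners match here, the large step seen with bromo should also hold with chloro. One gap remains: compound 4 has a hydrogen atom where compound 1 has a carbon atom, and no measurement covers that difference.

The expected step is large and upward: a number 82 percentage points higher from compound 2 to compound 4 (beyond the scatter). The estimate for compound 4 is 94%, with an expected range from 80% to 100%.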

Compound 4, percent of the compound remaining: 101%
Compound 4: the middle estimate sits 7 percentage points below what was measured, outside the stated range (above it).
By their numbers in this assay, from the lowest: compounds 3 and 2 (each within the scatter of the next); then compounds 1 and 4 (each within the scatter of the next).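

In this assay, the chloro pair now gives directly what could earlier only be inferred from the bromo pair: with a hydrogen atom in place of the group of 7 heavy atoms, the step is a number 89 percentage points higher from compound 2 to compound 4 (beyond the scatter) on the saturated chain carbon bound to an oxygen next to a carbonyl group. With 4-chloro-2-(methoxycarbonyl)phenyl in place of 4-bromo-2-(ethoxycarbonyl)phenyl, the step is a number 2.6 percentage points higher from compound 1 to compound 4 (within the scatter) and the two cannot be told apart. Across these four compounds, low numbers go with that group in compounds 2 and 3, and high numbers with its absence in compounds 1 and 4, with no compound going against this.

The data shown give no explanation for this large gap. Also open, going by these compounds, is where a propyl chain, an amine or a carboxylic acid at this place would stand in this assay.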